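Aryl variation on the triazole nitrogen: antiproliferative notes

The source may hold more compounds than are shown below. What is called first, only, known or untested is meant among the compounds shown, and "the series" means these compounds.

Measured so far:
Compound 1 `CCc1ccccc1-n1nncc1CN1C(=O)C2(C(C#N)=C(N)Oc3c(N)cc4nc5ccccc5nc4c32)c2ccccc21` in a functional assay on HepG2 cells (Homo sapiens) for antiproliferative activity, read by MTT assay, with a stated time of 48 h (a lower number here means a stronger inhibitor, a higher number a weaker inhibitor), gives 17900 nM.
Compound 2 `COc1ccc(-n2nncc2CN2C(=O)C3(C(C#N)=C(N)Oc4c(N)cc5nc6ccccc6nc5c43)c3ccccc32)cc1` in this assay reaches only the assay limit, > 50000 nM; this is a limit, not a number.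
Compound 3 `CCOc1ccccc1-n1nncc1CN1C(=O)C2(C(C#N)=C(N)Oc3c(N)cc4nc5ccccc5nc4c32)c2ccccc21` in this assay gives 30500 nM.

Among the two numbers, compound 3 carries the higher one, with compound 1 nearest; that gap, a 1.7-fold higher number from compound 1 to compound 3 (0.23 log units; within the scatter), lies within the scatter. Within the data shown here, the step of an at least 1.6-fold lower number from compound 2 to compound 3 (0.21 log units; that floor lies within the scatter) has a floor that also lies within the scatter, so the aryl group on the triazole nitrogen has so far moved the read-out only modestly; the one step that clearly counts is an at least 2.7-fold higher number from compound 1 to compound 2 (0.44 log units; beyond the scatter), and its starting point for compound 2 is a limit (the limit of > 50000 nM in this assay, at which 1 of the 3 values shown sits).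

Compound 4 `Cc1cc(C)cc(-n2nncc2CN2C(=O)C3(C(C#N)=C(N)Oc4c(N)cc5nc6ccccc6nc5c43)c3ccccc32)c1` differs from compound 3 as follows: 3,5-dimethylphenyl in place of 2-ethoxyphenyl on an aromatic nitrogen. The nearest measured steps are the ethoxy-for-ethyl swap within the scatter and the ring-substitution swap from compound 2 to compound 3 with a floor within the scatter. Neither suggests a large move in this assay, and the limit for compound 2 warns that a weaker outcome is possible. Compound 4 is therefore expected near compound 3, with a 1.2-fold lower number from compound 3 to compound 4 (0.09 log units; within the scatter), giving an estimated 25000 nM, in the range 9000 nM to 60000 nM.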

Compound 4, half-maximal inhibitory concentration: > 50000 nM
Compound 4: a limit, no number (the forecaster's own chance of this, stated with the estimate: 30%); middle value at least 2.0-fold (0.30 log units) from the limit.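

In this assay compound 4 reaches only a limit, > 50000 nM, so a second aryl group on the aromatic nitrogen now ends at that limit, after the 4-methoxyphenyl of compound 2: the limit of > 50000 nM in this assay, at which 2 of the 4 values shown sit.

Set against the 2-ethylphenyl group, the 3,5-dimethylphenyl group gives an at least 2.7-fold higher number from compound 1 to compound 4 (0.44 log units; beyond the scatter), a second step that counts, whereas against the 2-ethoxyphenyl group it gives an at least 1.6-fold higher number from compound 3 to compound 4 (0.21 log units; that floor lies within the scatter), so that comparison alone does not separate the two. Across the four compounds shown, the two aryl groups named with a single 2-substituent, in compound 1 and compound 3, return numbers, while the 4-methoxyphenyl and 3,5-dimethylphenyl groups, in compound 2 and compound 4, do not; no compound here goes against this, but it rests on four aryl groups only.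

The step between compound 2 and compound 4 joins two limits and cannot be read, so these two stay unordered. Still open, from the compounds shown here alone, is whether a 2-aminophenyl group, a 2-carboxyphenyl group or a longer chain such as 2-butoxyphenyl on that nitrogen would also return a number in this assay, and whether any such group would improve on the values seen so far.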